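Series notes: pyrazinyl in place of methylfuranyl on the shared core

The compounds below may be only part of what the source reports. "The series", "measured", "known", "first", "only" and "open" are said of these compounds alone.

Measured so far in a functional assay on CHO-K1 cells for antagonist activity at adenosine receptor A1 (Homo sapiens), read by a beta-galactosidase reporter and cAMP accumulation, with stated times of 15 min and 6 h; a higher number here means a weaker inhibitor, a lower number a stronger inhibitor:
compound 1 `Cc1ccc(-c2nc(N)c3cc(-c4ccccc4)sc3n2)o1`: 520 nM
compound 2 `Cc1ccc(-c2nc(N)c3cc(Cc4ccccc4)sc3n2)o1`: 298 nM
compound 3 `Cc1ccc(-c2nc(N)c3cc(C(C)c4ccccc4)sc3n2)o1`: 439 nM

Compound 2 shows the lowest of the three numbers, yet its gaps to the others lie within the scatter: a 1.5-fold higher number from compound 2 to compound 3 (0.17 log units; within the scatter) and a 1.7-fold lower number from compound 1 to compound 2 (0.24 log units; within the scatter) in the opposite sense. Compound 4 `Nc1nc(-c2cnccn2)nc2sc(Cc3ccccc3)cc12` differs from compound 2 by pyrazin-2-yl in place of 5-methylfuran-2-yl on an aromatic carbon. Among the measured compounds shown here, every measured step so far alters a different place on the shared core, so none bears directly on this exchange; they only show that this assay has tolerated modest changes without movement beyond the scatter. No step beyond the scatter is therefore expected in this assay, in either direction. For compound 4 the estimate is 350 nM, with a range of 90 nM to 1400 nM. The expected step is a 1.2-fold higher number from compound 2 to compound 4 (0.07 log units; within the scatter).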

Compound 4, inhibition constant: 91 nM
Beside the measured number, compound 4's estimate is 3.8-fold (0.59 log units) above it, within the range that was stated.
By their numbers in this assay, from the lowest: compound 4; then compounds 2, 3 and 1 (each within the scatter of the next).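

Among the compounds shown here, this place on the shared core, an aromatic carbon between two ring nitrogen atoms, gives the only step beyond the scatter so far in this assay with a 3.3-fold lower number from compound 2 to compound 4 (0.52 log units; beyond the scatter) for pyrazin-2-yl in place of 5-methylfuran-2-yl. The three earlier compounds all carry 5-methylfuran-2-yl and stay within the scatter of one another, so this place responds where the changes elsewhere did not. Nothing at hand accounts for the step.

Still open, as far as these compounds go, is whether pyridin-2-yl or unsubstituted phenyl at this place would match pyrazin-2-yl. Also open, from the compounds shown here alone, is whether the step carries over to the phenyl and 1-phenylethyl compounds.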